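Extending the amine tail of compound 1

The source may report more compounds than this note shows. Statements on the series, on what has been measured and on what is new or still open speak of the compounds shown alone.

Measured so far:
compound 1 `CCN(CC)c1nc(C)c2[nH]c(SCC(=O)NCCCN)nc2n1`: > 100 uM
compound 2 `CCN(CC)c1nc(C)c2[nH]c(SCC(=O)NCCN)[n+](CCCN(C)C)c2n1`: > 100 uM

In an ADME assay on CEM174 cells (Homo sapiens) for cytotoxicity (on this read-out lower numbers stand for higher toxicity in this test and higher numbers for lower toxicity in this test), compound 1 gives > 100 uM, which is a limit of the test rather than a number. Compound 2 likewise reaches > 100 uM, again a limit. Both results sit at the limit of > 100 uM in this assay, at which 2 of the 2 values shown sit, so compound 1 stands at the edge of what this test can resolve. Compound 3 `CCN(CC)c1nc(C)c2[nH]c(SCC(=O)NCCCNC(=N)N)nc2n1` differs from compound 1 by a group of 3 heavy atoms (1 carbon, 2 nitrogen; no ring) in place of a hydrogen atom, on an amine nitrogen. Among the compounds with values here, no step between measured compounds is known, so the expected step that the limit leaves unreadable from compound 1 to compound 3 is none beyond the scatter. Compound 3 is expected to give 150 uM, with a range from 60 uM to 400 uM.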

Compound 3, half-maximal toxic concentration: > 100 uM
Compound 3 gave a limit, no number; the forecaster's own chance of this, stated with the estimate: 80%; the middle value lies beyond the limit too.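

Within the data shown here, compound 1 and compound 3 both end at a limit of the test rather than a number, so no step between them can be read: the limit of > 100 uM in this assay, at which 3 of the 3 values shown sit. The compounds shown leave open whether the group added on the amine nitrogen changes the result in this assay at all.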